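The source may hold more compounds than are shown below. What is called first, only, known or untested is meant among the compounds shown, and "the series" means these compounds.

Of the compounds shown here, two that share one core have been measured so far in a physicochemical assay for acid dissociation. Compound 1 `Cc1c(N2CCCCCC2)nc(C2CC2)nc1N1CC(C)C1` gives 8, and compound 2 `Cc1c(N2CCCCCC2)nc(C2CC2)nc1N1CC(C)(C)C1` gives 7, the lower of the two numbers. The next compound, compound 3 `Cc1c(N2CCCCCC2)nc(C2CC2)nc1N1CC(C#N)C1`, keeps that core but carries 3-cyanoazetidin-1-yl in place of the 3,3-dimethylazetidin-1-yl of compound 2, on an aromatic carbon: 3-cyanoazetidin-1-yl in place of 3,3-dimethylazetidin-1-yl on an aromatic carbon.

Going by the values given here, only one measured step bears on this change. Putting methyl in place of hydrogen on a saturated ring carbon of the same four-membered ring gave a number 1.00 log units lower from compound 1 to compound 2 (beyond the scatter), a modest move beyond the scatter. Among the compounds with values here, no measured compound carries a nitrile, so this single step is only a rough guide to size. Taking it as that guide, a further move in the same direction is expected in this assay, probably somewhat smaller, although a change within the scatter cannot be ruled out. The expected step is a number 0.70 log units lower from compound 2 to compound 3 (beyond the scatter). For compound 3 the estimate is 6.3, with an expected range from 5.2 to 7.3.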

Compound 3, acid dissociation constant: 6.4
Beside the measured number, compound 3's estimate is 0.10 log units below it; low and high end bracket the measured number.
By their numbers in this assay, from the lowest: compound 3; then compound 2; then compound 1.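

In this assay, 3-cyanoazetidin-1-yl in place of 3,3-dimethylazetidin-1-yl gives a number 0.60 log units lower from compound 2 to compound 3 (beyond the scatter), so the number at this position can go lower than the dimethyl ring took it, and a group other than methyl can bring that about. Cyano in place of methyl on a saturated ring carbon gives a number 1.60 log units lower from compound 1 to compound 3 (beyond the scatter), a large step, which shows that a swap of one small group on the four-membered ring, with the rest of the shared core left as it is, can shift this read-out by more than the methyl step did. Nothing available here explains why the number falls with either change.

As far as these compounds go, three compounds give only a first outline, so it stays open where groups such as a fluorine, a hydroxyl, an amine, a carboxylic acid or a longer chain on the same ring carbon would fall relative to the nitrile and the two methyl groups. From the compounds shown here alone, it is also open whether these steps would keep their direction and size if the azepan-1-yl or cyclopropyl group on the core were exchanged for another group.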